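Removing the ring fluorine: an expected clearance for compound 4

The compounds below may be only part of what the source reports. "The series", "measured", "known", "first", "only" and "open" are said of these compounds alone.

Compound 1 `O=C(Nc1cc(-c2ccccn2)n[nH]1)N1CCC(c2ccc(Cl)cc2)CC1`: 30 mL.min-1.g-1
Compound 2 `O=C(Nc1cc(-c2ccccn2)n[nH]1)N1CCC(c2ccc(F)cc2)CC1`: 42.5 mL.min-1.g-1
Compound 3 `COc1ccc(C(=O)Nc2[nH]nc(-c3ccccn3)c2C2CC2)cc1`: 12.8 mL.min-1.g-1

In an ADME assay on liver for metabolic stability, with Liver microsome (Homo sapiens) as the target, using microsomes (on this read-out lower numbers stand for slow clearance and higher numbers for fast clearance), compound 2 gives the top number of the three, but compound 1 is within the usual scatter of it, so only compound 3 lies clearly lower. Compound 4 `O=C(Nc1cc(-c2ccccn2)n[nH]1)N1CCC(c2ccccc2)CC1` is compound 2 with hydrogen in place of fluoro on an aromatic carbon. Among the measured compounds shown here, the one measured step that touches this same aromatic carbon is a 1.4-fold higher number from compound 1 to compound 2 (0.15 log units; within the scatter), a swap of one halogen for another that barely moved the number. For the measured compounds named here, no measured step covers a hydrogen there, so nothing beyond the scatter is expected in this assay. Compound 4 is therefore estimated at 45 mL.min-1.g-1, with a range from 22 mL.min-1.g-1 to 90 mL.min-1.g-1. That estimate amounts to an expected step of a 1.1-fold higher number from compound 2 to compound 4 (0.02 log units; within the scatter).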

Compound 4, intrinsic clearance in microsomes: 15.3 mL.min-1.g-1
For compound 4 the middle estimate is 2.9-fold (0.47 log units) above the measured one; measured number below the stated range.
By their numbers in this assay, from the lowest: compounds 3, 4, 1 and 2 (each within the scatter of the next, the first and the last beyond it).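

Among the compounds shown here, on this aromatic carbon, the change from 4-fluorophenyl to phenyl gives a 2.8-fold lower number from compound 2 to compound 4 (0.44 log units; beyond the scatter) in this assay, the first step at this position to pass the usual scatter. The same hydrogen set against chloro gives a 2.0-fold lower number from compound 1 to compound 4 (0.29 log units; within the scatter), which stays within the scatter, so of the two halogen compounds only compound 2 stands clearly apart from compound 4. Nothing available explains this difference.

The compounds shown leave open how a nitrile or an amine on this same carbon would read in this assay. They also leave open whether fluoro elsewhere on this ring would give a similar step.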